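Acylguanidine series: aryl ether in place of biaryl

This account rests on a few compounds, and the source may have more. Where it says the series, first, only, none or still open, it means among the compounds named here.

Of the compounds shown here, two of the shared core have numbers so far. Compound 1 `CCc1cc(Cl)c(S(C)(=O)=O)cc1C(=O)N=C(N)N` gives 63 nM in a functional assay for inhibition of sodium/hydrogen exchanger (Oryctolagus cuniculus); a higher number here means a weaker inhibitor, a lower number a stronger inhibitor. Compound 2 `Cc1cc(-c2cc(Cl)cc(Cl)c2)c(S(C)(=O)=O)cc1C(=O)N=C(N)N` gives 130 nM in this assay, the higher of the two numbers; its gap to compound 1 lies beyond the usual scatter of this assay.

Compound 3 `Cc1cc(Oc2ccccc2Cl)c(S(C)(=O)=O)cc1C(=O)N=C(N)N` is not yet measured. It differs from compound 2 in one place: 2-chlorophenoxy in place of 3,5-dichlorophenyl on an aromatic carbon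

Going by the values given here, no step between two measured compounds covers a change of this kind, so the size of the step is open. A modest step in either direction, or none beyond the scatter, is expected; the estimate a 1.3-fold lower number from compound 2 to compound 3 (0.11 log units; within the scatter) sits close to the value of compound 2, with a wide range on both sides. Compound 3 is thus expected to give about 100 nM in this assay, between 40 nM and 300 nM.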

Compound 3, half-maximal inhibitory concentration: 14 nM
Compound 3: the middle estimate sits 7.1-fold (0.85 log units) above what was measured; the measured number lies below the stated range.
By their numbers in this assay, from the lowest: compound 3; then compound 1; then compound 2.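

In this assay, putting 2-chlorophenoxy in place of 3,5-dichlorophenyl on the aromatic carbon ortho to the methylsulfonyl group gives a 9.3-fold lower number from compound 2 to compound 3 (0.97 log units; beyond the scatter). This position therefore distinguishes between two groups of equal heavy-atom count, each with one six-membered aromatic ring of carbon only, though the change alters the attachment, the number of chlorines and their placement all at once. Nothing at hand bears on the reason for the step.

Still open, on these data alone, is how the step divides between the oxygen link and the chlorine pattern, which unsubstituted phenoxy, 3,5-dichlorophenoxy or 2-chlorophenyl at this carbon could separate. Also open, as far as these compounds go, is how groups without an aromatic ring, such as cyclohexyloxy or piperidine, would read at this position.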